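The source may hold more compounds than are shown below. What is called first, only, known or untested is meant among the compounds shown, and "the series" means these compounds.

Compound 1 `Cc1cc(C)nc(N2CCN(c3ccn4c(CC(F)(F)F)cnc4c3C#N)CC2)n1` is the starting point. In a functional assay on CHO cells with metabotropic glutamate receptor 2 (Homo sapiens) as the target, read by GTPgammaS binding (on this read-out higher numbers stand for larger maximal responses and lower numbers for smaller maximal responses), compound 1 reaches 128%, the lower of the two values measured, while compound 2 `CCc1cnc2c(C#N)c(N3CCN(c4nc(C)cc(C)n4)CC3)ccn12` reaches 142%. Going by the values given here, the one measured step links these two: a number 14 percentage points higher from compound 1 to compound 2 (beyond the scatter). That change sits on the saturated chain carbon bound to the core, not on the ring attached to the amine nitrogen.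

Compound 3 `N#Cc1c(N2CCN(c3ncccn3)CC2)ccn2c(CC(F)(F)F)cnc12` is not yet measured. It differs from compound 1 in one place: pyrimidin-2-yl in place of 4,6-dimethylpyrimidin-2-yl on an amine nitrogen in a ring. Among the compounds with values here, no measured step concerns this ring, so the step from compound 1 to compound 2 offers no direct guide, and the size of the change in this assay cannot be read from the data. A step of no more than the usual scatter is therefore expected from compound 1 to compound 3, a number 6 percentage points lower from compound 1 to compound 3 (within the scatter), with real uncertainty in either direction. Compound 3 is estimated to reach 122% in this assay, within a range from 95% to 148%.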

Compound 3, largest response reached (Emax), in percent of the reference or control that the assay uses: 231%
Compound 3: the middle estimate sits 109 percentage points below what was measured; measured number outside the range, above it.
By their numbers in this assay, from the lowest: compound 1; then compound 2; then compound 3.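

Swapping 4,6-dimethylpyrimidin-2-yl for pyrimidin-2-yl on the amine nitrogen in the ring gives a number 103 percentage points higher from compound 1 to compound 3 (beyond the scatter) in this assay and so counts as a large step. Going by these compounds alone, this shows that the group on this nitrogen, which no earlier step touched, has a strong bearing on the maximal response. The step also far outweighs the modest change on the saturated chain carbon, a number 14 percentage points higher from compound 1 to compound 2 (beyond the scatter) on the same read-out. The data offer nothing that explains why this change matters so much.

The compounds shown leave open whether a single methyl on the pyrimidin-2-yl ring, or a chlorine or methoxy group there, would keep this high response. They also leave open whether the same swap would bring a step of similar size on compound 2.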